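From a Cyanobutyl Chain to an Imidazolyl Ring

The source may hold more compounds than are shown below. What is called first, only, known or untested is meant among the compounds shown, and "the series" means these compounds.

Of the compounds shown here, three built on one shared core have been measured in a physicochemical assay for solubility, in phosphate buffer, with a stated time of 18 h; a higher number here means a more soluble compound, a lower number a less soluble compound. Compound 1 `N#Cc1c(N)nc2nc(C3CCC3)ncc2c1N` gives 217000 nM in this assay. Compound 2 `N#Cc1c(N)nc2nc(C3CCCCC3)ncc2c1N` gives 81000 nM. Compound 3 `CC(C)(C)c1nc(CCCCC#N)c2c(N)c(C#N)c(N)nc2n1` gives 16000 nM. Among the measured compounds shown here, the only pair of close neighbours among them shows a 2.7-fold lower number from compound 1 to compound 2 (0.43 log units; beyond the scatter), a modest step. Compound 3 stands lowest of the three numbers: compound 2 sits above it by a margin beyond the scatter, and compound 1 further above still.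

Compound 4 `CC(C)(C)c1nc(-c2ncc[nH]2)c2c(N)c(C#N)c(N)nc2n1` has not yet been measured. It differs from compound 3 by 1H-imidazol-2-yl in place of 4-cyanobutyl on an aromatic carbon. For the measured compounds named here, no measured step bears directly on this change: the single step in hand puts cyclohexyl in place of cyclobutyl on the core, a swap of one ring for another, and it tells nothing about a chain giving way to an aromatic ring at the position in question. Going by the values given here, with no comparable precedent, the expected step of a 1.4-fold higher number from compound 3 to compound 4 (0.14 log units; within the scatter) is kept small, and its direction is left open, the range being widened to reflect that. Compound 4 is therefore expected to give about 22000 nM in this assay, with a range from 7000 nM to 70000 nM.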

Compound 4, solubility: < 1000 nM
Compound 4: no number, only a limit; the forecaster's own chance of this, stated with the estimate: 5%; middle value at least 22-fold (1.34 log units) from the limit.
By their numbers in this assay, from the lowest: compound 3; then compound 2; then compound 1. At a limit, below all of these: compound 4.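

The position next to the ring nitrogen, meta to a tert-butyl group, proves far from indifferent in this assay: putting 1H-imidazol-2-yl in place of 4-cyanobutyl gives an at least 16-fold lower number from compound 3 to compound 4 (1.20 log units; beyond the scatter), a large step and beyond the scatter. Compound 4 gives no number here, only a limit of the assay, so this step marks a minimum size and not an exact one: the limit of < 1000 nM in this assay, at which 1 of the 4 values shown sits. The earlier step, cyclohexyl in place of cyclobutyl, exchanged one ring for another, whereas this change replaces a chain with no ring by a five-membered aromatic ring with 2 hetero atoms, and it shows that such an exchange at this position can carry a large step in this read-out.

The compounds shown leave open how far compound 4 lies beyond its limit and whether the step goes with the aromatic ring itself or with the hydrogen-bond donor that enters alongside it, since the two arrive together in this one pair. A phenyl ring or a 1-methylimidazol-2-yl group at this position would pull those two features apart.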